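The source may report more compounds than this note shows. Statements on the series, on what has been measured and on what is new or still open speak of the compounds shown alone.

Compound 1, `CCC(C)(C)Cc1c[nH]c(CCc2ccc(-c3cccc(N)n3)cc2)n1`, in a functional assay on HEK293 cells for agonist activity at Bombesin receptor subtype-3 (Mus musculus), read by luminescence and calcium flux, with a stated time of 10 min (on this read-out higher numbers stand for an effect only at larger amounts of compound and lower numbers for an effect already at smaller amounts), compound 1 gives 119 nM.
Compound 2, `CCC(C)(C)Cc1c[nH]c(CCc2ccc(-c3cnsc3)cc2)n1`, in this assay compound 2 gives 119 nM.
Compound 3, `CCC(C)(C)Cc1c[nH]c(CCc2ccc(-n3cncn3)cc2)n1`, in this assay compound 3 gives 121 nM.

Compound 3 stands level with the other two: a 1.0-fold higher number from compound 1 to compound 3 (0.01 log units; within the scatter) and a 1.0-fold higher number from compound 2 to compound 3 (0.01 log units; within the scatter), so nothing separates the three beyond the scatter of this assay. Compound 4, `CCC(C)(C)Cc1c[nH]c(CCc2ccc(N3CCCCC3)cc2)n1`, has not been measured. It differs from compound 3 only at one place: piperidin-1-yl in place of 1H-1,2,4-triazol-1-yl on an aromatic carbon.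

For the measured compounds named here, the steps that bear on this position are no change at the digits printed from compound 1 to compound 2 (within the scatter), a 1.0-fold higher number from compound 1 to compound 3 (0.01 log units; within the scatter) and a 1.0-fold higher number from compound 2 to compound 3 (0.01 log units; within the scatter). In each case a five- or six-membered aromatic group at this position was exchanged for another, and in each case the number in this assay did not move beyond the scatter. Going by the values given here, the change to compound 4 is of a different kind, since a non-aromatic ring with one hetero atom enters where an aromatic ring with three hetero atoms leaves, and none of the measured compounds carries a non-aromatic group at this position. The three measured steps therefore give no reason to expect a step beyond the scatter, while leaving the direction of any larger shift open. Compound 4 is expected to give about 130 nM in this assay, with a range from 45 nM to 400 nM, which is a 1.1-fold higher number from compound 3 to compound 4 (0.03 log units; within the scatter).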

Compound 4, half-maximal effective concentration: 133 nM
Compound 4: the middle estimate sits 1.0-fold (0.01 log units) below what was measured; measured number inside the range.
By their numbers in this assay, from the lowest: compounds 1, 2, 3 and 4 (each within the scatter of the next).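

With piperidin-1-yl, the set now holds a six-membered non-aromatic ring at this place, on an aromatic carbon para to a large group, and in this assay its exchange for 1H-1,2,4-triazol-1-yl gives a 1.1-fold higher number from compound 3 to compound 4 (0.04 log units; within the scatter). The exchanges for the two other aromatic groups read the same way, with a 1.1-fold higher number from compound 2 to compound 4 (0.05 log units; within the scatter) and a 1.1-fold higher number from compound 1 to compound 4 (0.05 log units; within the scatter). Across these four compounds, then, neither a non-aromatic ring in place of an aromatic one nor a change from three hydrogen-bond acceptors to one in the group separates the numbers beyond the scatter, and none of the four goes against this.

Nothing at hand accounts for why the number stays so flat at this position. As far as these compounds go, whether a carboxylic acid, an open-chain amine such as dimethylamino, a longer alkyl chain or a plain hydrogen at this place would also stay within the scatter remains open, as does whether the same holds when other parts of the shared core are changed.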